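Swapping a pyridinyl arm for benzimidazolyl on an antiproliferative core

The source may report more compounds than this note shows. Statements on the series, on what has been measured and on what is new or still open speak of the compounds shown alone.

Compound 1, `CCN(c1ccc(C#N)c(Cl)c1)c1cc(-c2cccnc2)ccc1C`: 2000 nM
Compound 2, `N#Cc1ccc(N2CCCc3c(-c4ccncc4)cccc32)cc1C(F)(F)F`: 15000 nM
Compound 3, `CCN(c1ccc(C#N)c(C(F)(F)F)c1)c1cc(-n2ccnc2)ccc1C`: 16300 nM

In a functional assay on CWR22R cells (Homo sapiens) for antiproliferative activity, read by CCK-8 assay, with a stated time of 6 days (a lower number here means a stronger inhibitor, a higher number a weaker inhibitor), compound 1 gives the lowest number of the three, and the numbers of compound 2 and compound 3 both lie well beyond the usual scatter above it. Compound 1 is therefore the strongest inhibitor in this set, though the pairs differ in more than one place, so no single change explains the gaps.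

Compound 4 is `CCN(c1ccc(C#N)c(Cl)c1)c1cc(-n2cnc3ccccc32)ccc1C`. It differs from compound 1 in one place: 1H-benzimidazol-1-yl in place of pyridin-3-yl on an aromatic carbon. Going by the values given here, no measured pair shows this kind of change alone, so the expectation rests on the shared core. The expected step for compound 4 is a 2.0-fold higher number from compound 1 to compound 4 (0.30 log units; within the scatter), a modest loss. Compound 4 is estimated at 4000 nM, in the range 1000 nM to 16000 nM.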

Compound 4, half-maximal inhibitory concentration: 3040 nM
Beside the measured number, compound 4's estimate is 1.3-fold (0.12 log units) above it; low and high end bracket the measured number.
By their numbers in this assay, from the lowest: compounds 1 and 4 (each within the scatter of the next); then compounds 2 and 3 (each within the scatter of the next).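

Replacing pyridin-3-yl with 1H-benzimidazol-1-yl gives a 1.5-fold higher number from compound 1 to compound 4 (0.18 log units; within the scatter) in this assay and so leaves the reading within the scatter. This aromatic carbon of the shared core therefore accepts a group with more heavy atoms and a second ring, and the two groups cannot be told apart here. Nothing available explains this result. Still open, on these data alone, is whether an amine or a carboxylic acid on this same carbon would be accepted as well. As far as these compounds go, it is also open whether a benzimidazolyl group would read the same with trifluoromethyl on the nitrile-bearing ring.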